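This account rests on a few compounds, and the source may have more. Where it says the series, first, only, none or still open, it means among the compounds named here.

Measured compounds and values:
- compound 1, `O=C(c1cc2cnc(Nc3ccc(N4CCNCC4)cn3)nc2n1C1CCCC1)N1CCCCC1`: 39600 nM
- compound 2, `O=C(Nc1ccccc1)c1cc2cnc(Nc3ccc(N4CCNCC4)cn3)nc2n1C1CCCC1`: 2800 nM
- compound 3, `COc1ccccc1NC(=O)c1cc2cnc(Nc3ccc(N4CCNCC4)cn3)nc2n1C1CCCC1`: 1830 nM

In a functional assay on MIA PaCa-2 cells (Homo sapiens) for inhibition, read by MTT assay (on this read-out lower numbers stand for stronger inhibition and higher numbers for weaker inhibition), compound 3 gives the lowest of the three numbers, but its distance to compound 2 is small: a 1.5-fold lower number from compound 2 to compound 3 (0.18 log units; within the scatter), so the two cannot be told apart. Both stand far from compound 1, as a 14-fold lower number from compound 1 to compound 2 (1.15 log units; beyond the scatter) and a 22-fold lower number from compound 1 to compound 3 (1.34 log units; beyond the scatter) show.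

Compound 4, `COc1ccc(NC(=O)c2cc3cnc(Nc4ccc(N5CCNCC5)cn4)nc3n2C2CCCC2)c(OC)c1`, differs from compound 3 in one place: methoxy in place of hydrogen on an aromatic carbon. Among the measured compounds shown here, the only measured step that bears on this kind of change is the one from compound 2 to compound 3, where a methoxy group also replaced a hydrogen on an aromatic carbon, and that step stayed within the scatter: a 1.5-fold lower number from compound 2 to compound 3 (0.18 log units; within the scatter). For the measured compounds named here, there is no measured example of a second methoxy group on this ring. On that basis no step beyond the scatter is expected in this assay, in either direction.

Compound 4 is therefore estimated at 1800 nM, with a range from 700 nM to 4500 nM. This estimate means an expected step of a 1.0-fold lower number from compound 3 to compound 4 (0.01 log units; within the scatter).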

Compound 4, half-maximal inhibitory concentration: 2230 nM
Compound 4: the middle estimate sits 1.2-fold (0.09 log units) below what was measured, within the range that was stated.
By their numbers in this assay, from the lowest: compounds 3, 4 and 2 (each within the scatter of the next); then compound 1.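

In this assay, adding a second methoxy group to the (2-methoxyphenyl)amino ring, meta to the first methoxy group and para to a large group, produces no change that can be told from scatter (a 1.2-fold higher number from compound 3 to compound 4 (0.09 log units; within the scatter)). The same holds when the 2,4-dimethoxyphenyl group is compared with plain phenyl on the amide-type nitrogen (a 1.3-fold lower number from compound 2 to compound 4 (0.10 log units; within the scatter)), whereas the comparison with the piperidin-1-yl amide still shows a large step (an 18-fold lower number from compound 1 to compound 4 (1.25 log units; beyond the scatter)), so among these compounds the large steps appear only on replacing piperidin-1-yl with an arylamino group. Nothing available here explains why the methoxy groups make so little difference.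

On these data alone, it remains open whether a group of a different kind at this ring position, such as an amine or a carboxylic acid, would shift the number beyond the scatter. As far as these compounds go, a single methoxy group at this position, without the one already on the ring, also remains unknown.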